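A few compounds are considered here, and "the series" means these few. Any claim that something is new, unique, unknown or untested is made for them only; others in the source may bear on it.

Measured compounds:
- compound 1, `O=C1Nc2ccccc2C1(c1c[nH]c2ccc(Br)cc12)c1c[nH]c2ccc(Br)cc12`: 13200 nM
- compound 2, `O=C1Nc2ccccc2C1(c1c[nH]c2ccc([N+](=O)[O-])cc12)c1c[nH]c2ccc([N+](=O)[O-])cc12`: 11800 nM
- compound 3, `O=C1Nc2ccc(F)cc2C1(c1c[nH]c2ccc(Br)cc12)c1c[nH]c2ccc(Br)cc12`: 2800 nM

All three were tested in a functional assay on SK-N-SH cells (Homo sapiens) for cytotoxicity, read by MTT assay, with a stated time of 48 h; a lower number here means a stronger inhibitor, a higher number a weaker inhibitor. Compound 1 and compound 3 share a core and differ in one place only: fluoro in place of hydrogen on an aromatic carbon. That change gave a 4.7-fold lower number from compound 1 to compound 3 (0.67 log units; beyond the scatter), a clear step in the direction of stronger inhibition.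

Compound 2 carries a different core; how the core of compound 2 differs from the core of compound 1 is not broken down here. In this assay compound 2 gives a value that sits within the scatter of compound 1, so the two cannot be told apart on these data, while compound 3 gives a number well below both.

Compound 4, `O=C1Nc2ccc(F)cc2C1(c1c[nH]c2ccc([N+](=O)[O-])cc12)c1c[nH]c2ccc([N+](=O)[O-])cc12`, has not yet been measured in this assay. It relates to compound 2 as compound 3 relates to compound 1: fluoro in place of hydrogen on an aromatic carbon. The place of the change is the same in both pairs, so this is the same change made on a different core. For the measured compounds named here, the expectation for compound 4 rests on a single earlier step, because a 4.7-fold lower number from compound 1 to compound 3 (0.67 log units; beyond the scatter) is the only instance of this change among the measured compounds, and it is not known whether the second core responds in the same way.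

Taking compound 2 as the starting point, the expected step is a 3.9-fold lower number from compound 2 to compound 4 (0.59 log units; beyond the scatter), estimated to be of roughly the size seen before. On that basis compound 4 is expected to give about 3000 nM in this assay, with the estimate likely to fall between 1200 nM and 8000 nM.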

Compound 4, half-maximal inhibitory concentration: 6800 nM
Compound 4: the middle estimate sits 2.3-fold (0.36 log units) below what was measured; the range from low to high includes it.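

In this assay, for the compounds shown here, fluoro in place of hydrogen on an aromatic carbon gave a 1.7-fold lower number from compound 2 to compound 4 (0.24 log units; within the scatter), so on the core of compound 2 the change produced no step that can be told apart from the ordinary spread of repeated measurements. Going by these compounds alone, with only two pairs, this cannot show why the cores differ, nor which of the two steps a further core would resemble. What it does show is that the step seen on the first core did not carry over at the same size to the second, so one step on one core is a weak guide to the next:  the same change on two cores in this assay, a 4.7-fold lower number (0.67 log units; beyond the scatter) from compound 1 to compound 3 and a 1.7-fold lower number (0.24 log units; within the scatter) from compound 2 to compound 4, 2.7-fold (0.43 log units) apart, beyond the scatter of two such steps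

Still open, from the compounds shown here alone, is whether chloro or methoxy on the same aromatic carbon would give a step like either of these two. Going by these compounds, it is also open how the fluoro change would behave on a core carrying an amine or a carboxylic acid in place of the bromo or nitro groups.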